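The compounds below may be only part of what the source reports. "The series", "measured", "known", "first", "only" and "open" are said of these compounds alone.

Measured compounds:
- Compound 1 `COc1ccc(S(=O)(=O)Nc2ccc(CN3CCN(C(=O)C4CN(C(C)=O)C4)CC3)cc2)cc1` gives >= 511000 nM in a physicochemical assay for solubility, measured as kinetic solubility; a higher number here means a more soluble compound, a lower number a less soluble compound; this value is a limit of the assay, not a number.
- Compound 2 `Cc1ccc(S(=O)(=O)Nc2ccc(CNC3CN(C(=O)c4cccc(Cl)c4)C3)cc2)cc1` gives 70000 nM in this assay.
- Compound 3 `Cc1ccc(S(=O)(=O)Nc2ccc(CN3C[C@@H]4CN(C(=O)c5cccc(Cl)c5)C[C@@H]4C3)cc2)cc1` gives 25000 nM in this assay.

Compound 1 stands apart from the other two: it sits at the limit of >= 511000 nM in this assay, at which 1 of the 3 values shown sits, so only a floor for its solubility is known, while compound 2 and compound 3 each give a plain number well beneath that floor. Among the compounds with values here, compound 1 differs from them at several places at once, so no single-change step connects them, and nothing can be said about which of those differences matters.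

The step from compound 1 to compound 4 `COc1ccc(S(=O)(=O)Nc2ccc(CN3CCN(C(=O)C4CCCN(C)C4)CC3)cc2)cc1` changes one group only: 1-methylpiperidin-3-yl in place of 1-acetylazetidin-3-yl on a carbonyl carbon. Within the data shown here, no measured pair shows what such a change does in this assay. With compound 1 already at the limit, the only expectation that the data support is that compound 4 stays at or near that limit, and the step of a number no higher from compound 1 to compound 4 (the limit leaves the size open) is expected to be none beyond the scatter. Compound 4 is therefore expected to give about 511000 nM, within 200000 nM to 511000 nM, most likely again as a limit.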

Compound 4, solubility: >= 526000 nM
Compound 4: only a limit was reported; the forecaster's own chance of this, stated with the estimate: 70%; at least 1.0-fold (0.01 log units) between middle value and limit.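

Within the data shown here, compound 1 and compound 4 each give only a limit in this assay, not a plain number, and no step between them can be read. The compounds shown leave open what 1-methylpiperidin-3-yl in place of 1-acetylazetidin-3-yl on a carbonyl carbon does to solubility.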